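The source may report more compounds than this note shows. Statements on the series, on what has been measured and on what is new or still open speak of the compounds shown alone.

Compound 1 `COc1ccc(CS(=O)(=O)/C=C/c2ccc(OC)c(OC)c2OC)cc1[N+](=O)[O-]` and compound 2 `COc1cc(/C=C/S(=O)(=O)Cc2ccc(OC)c([N+](=O)[O-])c2)cc(OC)c1` share a common core and were both run in a functional assay on HCT-116 cells (Homo sapiens) for cytotoxicity, read by MTT assay, with a stated time of 72 h; a lower number here means a stronger inhibitor of growth, a higher number a weaker inhibitor of growth. In this assay compound 1 gives 27900 nM, a weak result. For compound 2 the assay reports only a limit, > 30000 nM, so no number is known for it. Where compound 2 stands is therefore described by the limit of > 30000 nM in this assay, at which 1 of the 2 values shown sits, rather than by a measured point, and the two compounds can only be said to be weak together, with no ordering between them.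

Compound 3 `COc1cc(/C=C/S(=O)(=O)Cc2ccc(OC)c(N)c2)cc(OC)c1` has not yet been measured. It differs from compound 2 in a single place: amino in place of nitro on an aromatic carbon, ortho to a methoxy group and meta to a large group. No measured pair among these compounds carries this change, so its size cannot be read off.

Compound 3 is expected to remain weak, and the step of an at least 1.0-fold lower number from compound 2 to compound 3 (0.02 log units; that floor lies within the scatter) is estimated to stay within the usual scatter, in no clear direction. Compound 3 is accordingly estimated at 28000 nM, with a range from 9000 nM to 90000 nM, and it may again return only as a limit.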

Compound 3, concentration for 50% growth inhibition: 540 nM
Compound 3: middle estimate off by 52-fold (1.71 log units), on the high side; measured number outside the range, below it.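

Amino in place of nitro on this aromatic carbon, ortho to a methoxy group and meta to a large group, gives an at least 55-fold lower number from compound 2 to compound 3 (1.74 log units; beyond the scatter) in this assay. This is the first step that can be read among these compounds, and it shows that growth inhibition in the cells depends strongly on the group at this position, although that rests on this single pair. Compound 2 is known only through a limit, so the step is a floor and its full size stays unknown: the limit of > 30000 nM in this assay, at which 1 of the 3 values shown sits.

What the compounds shown leave open is whether the gain comes from the amino group itself or simply from the loss of nitro, which a hydroxyl group, an acetamide or a dimethylamino group at the same carbon would help to separate. On these data alone, it also remains open whether the same change would carry over to the core of compound 1, with its different arrangement of methoxy groups, and nothing here tells why the change has so large an effect.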